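A few compounds are considered here, and "the series" means these few. Any claim that something is new, unique, unknown or untested is made for them only; others in the source may bear on it.

Among the measured compounds shown here, in a functional assay on CCRF-CEM cells (Homo sapiens) for cytotoxicity, in the presence of a further agent that is not named here (a lower number here means a stronger inhibitor, a higher number a weaker inhibitor), compound 2 (`COC(=O)c1ccc(CN(CCCc2c(N)nc(N)nc2O)c2cc(F)c(F)cc2[N+](=O)[O-])cc1`) gives 53000 nM, the higher of the two numbers so far. Compound 1 (`COC(=O)c1ccc(CN(CCCc2c(N)nc(N)nc2O)c2cc(F)c([N+](=O)[O-])cc2[N+](=O)[O-])cc1`) gives 3500 nM.

Compound 3 (`COC(=O)c1ccc(CN(CCCc2c(N)nc(N)nc2O)c2ccc([N+](=O)[O-])c(F)c2F)cc1`) is an isomer of compound 2, with the change confined to the group on the amine nitrogen: 2,3-difluoro-4-nitrophenyl in place of 4,5-difluoro-2-nitrophenyl on an amine nitrogen. In words, 2,3-difluoro-4-nitrophenyl replaces 4,5-difluoro-2-nitrophenyl.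

For the measured compounds named here, only one measured step bears on this: a 15-fold higher number from compound 1 to compound 2 (1.18 log units; beyond the scatter). It is large and shows that one replacement on this phenyl group can move the number well beyond the scatter. However, it swaps one group for another, whereas compound 3 keeps the groups of compound 2 and rearranges them. Going by the values given here, no measured pair shows the effect of such a rearrangement, so neither size nor direction is firmly set.

With compound 2 at the top of a two-compound span, a modest move toward a lower number is the working expectation, with a wide margin. The expected step is a 2.1-fold lower number from compound 2 to compound 3 (0.33 log units; beyond the scatter). For compound 3 the estimated value is 25000 nM, with an expected range of 6000 nM to 90000 nM.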

Compound 3, half-maximal inhibitory concentration: 45000 nM
Estimate against measurement, compound 3: 1.8-fold (0.26 log units) below; low and high end bracket the measured number.
By their numbers in this assay, from the lowest: compound 1; then compounds 3 and 2 (each within the scatter of the next).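

In this assay the rearrangement gives a 1.2-fold lower number from compound 2 to compound 3 (0.07 log units; within the scatter) and so, in this pair, 2,3-difluoro-4-nitrophenyl and 4,5-difluoro-2-nitrophenyl on the amine nitrogen cannot be told apart. The earlier step, a 15-fold higher number from compound 1 to compound 2 (1.18 log units; beyond the scatter) for fluoro in place of nitro, showed that replacing a group on this phenyl ring can shift the number beyond the scatter, whereas this pair shows that a rearrangement of the same groups need not; one step of each kind is too little to call this a pattern. No measurement is at hand that would account for either step.

Open, as far as these compounds go, is whether the same insensitivity to arrangement holds when the phenyl group carries other groups, such as chloro, a nitrile or an amine in place of fluoro, or two nitro groups as in compound 1. Also open, from the compounds shown here alone, is how far these readings carry over to compounds with a carboxylic acid in place of the methyl ester, or with a longer chain in place of the three-carbon link to the amine nitrogen.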